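The source may report more compounds than this note shows. Statements on the series, on what has been measured and on what is new or still open speak of the compounds shown alone.

Of the compounds shown here, three of one series have been tested in an ADME assay on Huh-7 cells (Homo sapiens) for cytotoxicity, read by colorimetric assay; on this read-out higher numbers stand for lower toxicity in this test and lower numbers for higher toxicity in this test. Compound 1 `COc1ccc2c(O[C@H]3C[C@H]4C(=O)N(C)CCCC/C=C/[C@@H]5C[C@@]5(C(=O)NS(=O)(=O)C5CC5)NC(=O)N4C3)cc(-c3nc(C4CC4)cs3)nc2c1Cl` gives 31300 nM. Compound 2 `COc1ccc2c(O[C@H]3C[C@H]4C(=O)N(C)CCCC/C=C/[C@@H]5C[C@@]5(C(=O)NS(=O)(=O)C5(C)CC5)NC(=O)N4C3)cc(-c3csc(C(C)C)n3)nc2c1Cl` gives 30200 nM. Compound 3 `COc1ccc2c(O[C@H]3C[C@H]4C(=O)N(C)CCCC/C=C/[C@@H]5C[C@@]5(C(=O)NS(=O)(=O)C5(C)CC5)NC(=O)N4C3)cc(-n3cc(C(C)C)cn3)nc2c1C` gives 9610 nM. Within these three numbers compound 2 holds the second highest place: its nearest neighbour is compound 1, whose number lies within the usual scatter of this assay, so the two cannot be told apart, while compound 3 sits beyond the scatter below compound 2. Compound 3 differs from compound 2 in more than one place, so its lower number cannot be pinned to a single change.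

Compound 4 `COc1ccc2c(O[C@H]3C[C@H]4C(=O)N(C)CCCC/C=C/[C@@H]5C[C@@]5(C(=O)NS(=O)(=O)C5(C)CC5)NC(=O)N4C3)cc(-c3nc(C#N)cs3)nc2c1Cl` has not yet been measured. It differs from compound 2 in one place: 4-cyano-1,3-thiazol-2-yl in place of 2-isopropyl-1,3-thiazol-4-yl on an aromatic carbon.

Going by the values given here, no pair of measured compounds differs by exactly this kind of change, so there is no directly comparable step to lean on. Compounds 1 and 2 carry two different groups at the same position and still give numbers within the scatter of each other, which suggests that this position tolerates variation without a clear shift. The step from compound 2 to compound 4 is therefore expected to stay within the scatter, as a 1.1-fold lower number from compound 2 to compound 4 (0.03 log units; within the scatter) indicates. Compound 4 is expected to give 28000 nM in this assay, within a range from 12000 nM to 60000 nM.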

Compound 4, half-maximal cytotoxic concentration: 75000 nM
For compound 4 the middle estimate is 2.7-fold (0.43 log units) below the measured one; measured number above the stated range.
By their numbers in this assay, from the lowest: compound 3; then compounds 2 and 1 (each within the scatter of the next); then compound 4.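

The earlier compounds shown here gave no single-change step at this position, and this result supplies the first: in this assay, replacing 2-isopropyl-1,3-thiazol-4-yl with 4-cyano-1,3-thiazol-2-yl gives a 2.5-fold higher number from compound 2 to compound 4 (0.40 log units; beyond the scatter). The position on the six-membered aromatic ring, next to the ring nitrogen, is therefore not indifferent to what it carries, and on this read-out the change goes towards lower toxicity in this test, although the step is modest. No measurement shown here explains the shift, and the single step joins two differences, as the ring is attached through a different atom and the isopropyl group gives way to a nitrile.

The compounds shown leave open which of those two differences matters, a question that a 4-isopropyl-1,3-thiazol-2-yl group at this position could help to separate from the effect of the nitrile. They also leave open whether the higher number would persist if the nitrile gave way to a carboxylic acid or an amine on the same thiazole ring.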